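The source may report more compounds than this note shows. Statements on the series, on what has been measured and on what is new or still open speak of the compounds shown alone.

Measured so far in a functional assay on Huh-7 cells (Homo sapiens) for antiproliferative activity, read by CCK-8 assay, with a stated time of 72 h; a lower number here means a stronger inhibitor of growth, a higher number a weaker inhibitor of growth:

- compound 1 `CCC1C(=O)N(C)c2cnc(Nc3ccc(S(=O)(=O)NCC(C)C)cc3)nc2N1c1ccn(C)n1` gives 8520 nM
- compound 2 `CC[C@@H]1C(=O)N(C)c2cnc(-n3ccc4cc(C(N)=O)ccc43)nc2N1C1CCCC1` gives 3090 nM
- compound 3 `CCC1C(=O)N(C)c2cnc(-n3ccc4cc(C(=O)NC(C)C)ccc43)nc2N1c1ccn(C)n1` gives 6740 nM

Compound 3 (6740 nM) cannot be told apart from compound 1 (8520 nM). The two values lie within the usual scatter of repeated measurements. Compound 2 (3090 nM) has the lowest number of the three, and its gap to compound 3 goes beyond that scatter. Compound 2 differs from compound 3 in more than one place, however, so this gap says nothing about any single change.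

Compound 4 `CCC1C(=O)N(C)c2cnc(-n3ccc4cc(C(=O)NC)ccc43)nc2N1c1ccn(C)n1` has not yet been measured. It keeps the whole of compound 3 except for one small change on the amide: methyl in place of isopropyl on an amide-type nitrogen. In words, this is methyl in place of isopropyl on an amide-type nitrogen. Among the compounds with values here, no measured pair of compounds isolates this change, so the data offer no direct guide to its effect. All three measured values fall in a fairly narrow band, from compound 2 at 3090 nM to compound 1 at 8520 nM, which points to a modest outcome. The expected result in this assay is an estimated 1.2-fold lower number from compound 3 to compound 4 (0.07 log units; within the scatter), with nothing beyond the scatter. The estimated value for compound 4 is 5800 nM, with an expected range from 2500 nM to 13000 nM.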

Compound 4, concentration for 50% growth inhibition: 13200 nM
For compound 4 the middle estimate is 2.3-fold (0.36 log units) below the measured one, outside the stated range (above it).
By their numbers in this assay, from the lowest: compound 2; then compounds 3, 1 and 4 (each within the scatter of the next).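

Within the data shown here, the first measured pair that differs in one place only, methyl in place of isopropyl on an amide-type nitrogen, gives in this assay a 2.0-fold higher number from compound 3 to compound 4 (0.29 log units; within the scatter). The two compounds therefore cannot be told apart, so this pair offers no sign that the choice between isopropylcarbamoyl and methylcarbamoyl matters for growth inhibition in these cells. Nothing measured here speaks to why the two groups read alike.

A longer chain, a benzyl group or a chain ending in an amine on this same amide nitrogen could still show whether the position responds to a larger change, and a carboxylic acid in place of the whole amide would test whether the amide itself is needed. One pair also cannot show whether methyl and isopropyl would stay indistinguishable if the rest of the molecule were different, so the result holds for this one pair and should not be read as a general rule for the series.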